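Mirror-image stereochemistry in the bicyclic urea series

The compounds below may be only part of what the source reports. "The series", "measured", "known", "first", "only" and "open" are said of these compounds alone.

Compound 3 `C[C@@H]1CN(CCCN(C(=O)Nc2cc(Cl)nc(Cl)c2)[C@@H]2CC[C@]3(c4cnc(CN)s4)CC23)[C@@H](C)CN1` gives 13.1 nM in a functional assay for antagonist activity at melanin-concentrating hormone receptor 1 (Homo sapiens) (on this read-out higher numbers stand for weaker inhibition and lower numbers for stronger inhibition), the lowest of the three numbers to hand, though none of the gaps to the others lies beyond the scatter. Compound 2 `C[C@@H]1CN(CCCN(C(=O)Nc2ccc(F)c(C(F)(F)F)c2)[C@@H]2CC[C@]3(c4cnc(CN)s4)CC23)[C@@H](C)CN1` gives 19 nM in this assay, and compound 1 `N#Cc1cccc([C@]23CC[C@@H](N(CCCN4CC[C@@H](O)C4)C(=O)Nc4ccc(F)c(Cl)c4)[C@H]2C3)c1` gives 22 nM in this assay. Going by the values given here, the only single-point step measured so far, a 1.5-fold lower number from compound 2 to compound 3 (0.16 log units; within the scatter), concerns an exchange of the aryl group on the urea nitrogen and is itself within the scatter.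

Compound 4 `C[C@@H]1CN[C@@H](C)CN1CCCN(C(=O)Nc1cc(Cl)nc(Cl)c1)[C@H]1CC[C@@]2(c3cnc(CN)s3)C[C@@H]12` differs from compound 3 in no atom or bond: the two compounds have the same atoms and bonds; at least one stereo element is drawn with a configuration in one of them and without one in the other: 5 of 5 stereo elements differ; a stereocentre at a saturated ring carbon is drawn S in compound 3 and R in compound 4; a stereocentre at a saturated ring carbon is drawn R in compound 3 and S in compound 4; a stereocentre at a saturated ring carbon is drawn R in compound 3 and S in compound 4; a stereocentre at a saturated ring carbon is drawn S in compound 3 and R in compound 4. It is thus the mirror-image form of compound 3 across all of its stereocentres.

Among the compounds with values here, no measured step in this set bears on an inversion of stereochemistry; the one step available, from compound 2 to compound 3, changes an aryl group and says nothing about the handedness of the core. Within the data shown here, the step to compound 4 therefore has no precedent here. Full inversion of a rigid core with several stereocentres commonly changes potency far more than any substituent exchange seen so far, most often toward weaker inhibition, so a step of a 23-fold higher number from compound 3 to compound 4 (1.36 log units; beyond the scatter) toward higher numbers is expected, with wide uncertainty. For compound 4 the estimate in this assay is 300 nM, expected to fall between 30 nM and 3000 nM.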

Compound 4, inhibition constant: 171 nM
Estimate against measurement, compound 4: 1.8-fold (0.24 log units) above; low and high end bracket the measured number.
By their numbers in this assay, from the lowest: compounds 3, 2 and 1 (each within the scatter of the next); then compound 4.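

In this assay the series now has its first step beyond the scatter, a 13-fold higher number from compound 3 to compound 4 (1.12 log units; beyond the scatter), whereas the exchange of the aryl group on the urea nitrogen, a 1.5-fold lower number from compound 2 to compound 3 (0.16 log units; within the scatter), stayed within it. Going by these compounds alone, with atoms and bonds unchanged, configuration alone moves this read-out more than the one aryl exchange available for comparison, yet the inverted form is not silent, since compound 4 still gives 171 nM. The step can be assigned to stereochemistry rather than to any substituent because the pair is separated by nothing else: the fact that one of compounds 3 and 4 is drawn with a defined configuration and the other without, at the place where they differ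

All the stereocentres change together between compound 3 and compound 4, so the share of any single centre, whether on the shared core or in the side chain, cannot be read from this pair. On these data alone, it also stays open whether inversion carries a step of similar size with the 4-fluoro-3-(trifluoromethyl)phenyl group of compound 2, or with a methoxy-substituted phenyl group on the urea nitrogen.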